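Fluorine on the benzyl amide: a small step from compound 3

The source may report more compounds than this note shows. Statements on the series, on what has been measured and on what is new or still open speak of the compounds shown alone.

Three close relatives share one core and differ only in the group on the amide nitrogen. Compound 1 `CNC(=O)c1cc(Oc2ccc(/C=C/c3ccccn3)cc2)ccn1` carries a methyl there; in a functional assay on A549 cells (Homo sapiens) for antiproliferative activity, read by CCK-8 assay, with a stated time of 48 h (a lower number here means a stronger inhibitor, a higher number a weaker inhibitor), compound 1 gives 17400 nM. Compound 2 `O=C(Nc1ccc(Cl)cc1)c1cc(Oc2ccc(/C=C/c3ccccn3)cc2)ccn1` carries a 4-chlorophenyl, and compound 2 gives 16200 nM. Compound 3 `O=C(NCc1ccccc1)c1cc(Oc2ccc(/C=C/c3ccccn3)cc2)ccn1` carries a benzyl, and compound 3 gives 18800 nM. All three numbers sit together: there is a 1.1-fold lower number from compound 1 to compound 2 (0.03 log units; within the scatter), a 1.1-fold higher number from compound 1 to compound 3 (0.03 log units; within the scatter) and a 1.2-fold higher number from compound 2 to compound 3 (0.06 log units; within the scatter), so compound 3 cannot be told apart from the other two in this assay.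

Compound 4 `O=C(NCc1ccc(F)cc1)c1cc(Oc2ccc(/C=C/c3ccccn3)cc2)ccn1` changes compound 3 by fluoro in place of hydrogen on an aromatic carbon; cut one bond further out, this reads benzyl to 4-fluorobenzyl. Going by the values given here, no measured step swaps fluoro for hydrogen, so none bears on this change directly. What the three steps do show is that much larger changes at the amide nitrogen, methyl to 4-chlorophenyl or to benzyl, left this assay unmoved beyond the scatter. A single fluorine added to the benzyl is a smaller alteration than any of those, so no step beyond the scatter is expected in either direction.

Compound 4 is therefore expected to give about 18000 nM, within a range from 9000 nM to 36000 nM. This estimate means a 1.0-fold lower number from compound 3 to compound 4 (0.02 log units; within the scatter).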

Compound 4, half-maximal inhibitory concentration: > 100000 nM
Compound 4: a limit, no number; the forecaster's own chance of this, stated with the estimate: 5%; middle value at least 5.5-fold (0.74 log units) from the limit.
By their numbers in this assay, from the lowest: compounds 2, 1 and 3 (each within the scatter of the next). At a limit, above all of these: compound 4.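

In this assay compound 4 stands at a limit of the assay, which is not a number: the limit of > 100000 nM in this assay, at which 1 of the 4 values shown sits. The step of an at least 5.3-fold higher number from compound 3 to compound 4 (0.72 log units; beyond the scatter) shows that a hydrogen on the aromatic ring of the benzyl group, para to a large group, is not a silent place: replacing it with a single fluoro changes the read-out beyond the scatter, although swapping methyl, 4-chlorophenyl and benzyl on the amide nitrogen did not. The other two comparisons agree, with an at least 5.7-fold higher number from compound 1 to compound 4 (0.75 log units; beyond the scatter) and an at least 6.1-fold higher number from compound 2 to compound 4 (0.79 log units; beyond the scatter), so 4-fluorobenzyl separates from all three earlier groups, and this small change counts for more here than the much larger ones did.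

The true size of these steps stays open, since the limit gives only a lower bound, and nothing shown here says what lies behind the loss of activity. As far as these compounds go, it also stays open whether this loss belongs to fluorine alone or would also follow from a chlorine, a methyl or a methoxy group at the same place on the benzyl ring.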